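The source may hold more compounds than are shown below. What is called first, only, known or untested is meant among the compounds shown, and "the series" means these compounds.

Measured compounds:
compound 1 `Cc1nn([C@H](C)c2ccc(Cl)cc2Cl)c2nc(N3CC[C@H](N4CCC[C@H]4C(N)=O)[C@H](C)C3)cnc12`, 170 nM in a functional assay on cells for antagonist activity at C-C chemokine receptor type 4 (Homo sapiens), read by fluorescence and calcium flux, with stated times of 2.5 s and 45 s; a higher number here means a weaker inhibitor, a lower number a stronger inhibitor
compound 2 `C[C@@H]1CC(c2cnc3c(C#N)nn([C@H](C)c4ccc(Cl)cc4Cl)c3n2)=CC[C@@H]1N1CCC[C@H]1C(C)(C)O`, 384 nM in this assay

Compound 1 holds the lowest of the two numbers in this assay; compound 2 sits higher by a margin beyond the scatter. Compound 3 `Cc1nn([C@H](C)c2ccc(Cl)cc2Cl)c2nc(N3CC[C@H](N4CCC[C@H]4CCC#N)[C@H](C)C3)cnc12` has not been measured. Its change from compound 1 is 2-cyanoethyl in place of carbamoyl on a saturated ring carbon, in words 2-cyanoethyl in place of carbamoyl on a saturated ring carbon, cut one bond further out 2-carbamoylpyrrolidin-1-yl to 2-(2-cyanoethyl)pyrrolidin-1-yl. Among the compounds with values here, no measured pair shows this step, so a modest upward move of a 1.6-fold higher number from compound 1 to compound 3 (0.22 log units; within the scatter) is expected, wide in range. Compound 3 is estimated at 280 nM in this assay, between 100 nM and 800 nM.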

Compound 3, half-maximal inhibitory concentration: 41 nM
Compound 3: the middle estimate sits 6.8-fold (0.83 log units) above what was measured, outside the stated range (below it).
By their numbers in this assay, from the lowest: compound 3; then compound 1; then compound 2.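

In this assay, 2-cyanoethyl in place of carbamoyl on this saturated ring carbon gives a 4.1-fold lower number from compound 1 to compound 3 (0.62 log units; beyond the scatter). Inhibition at this position therefore does not depend on the carbamoyl group or its hydrogen-bond donor, and the longer chain with a nitrile end is accepted. Nothing measured accounts for this gain.

Going by these compounds, whether the nitrile or the chain length matters more remains open; a plain propyl chain or a 2-aminoethyl group here would help separate the two. On these data alone, whether the gain carries over to the core of compound 2 is also open.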